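A few compounds are considered here, and "the series" means these few. Any claim that something is new, unique, unknown or untested is made for them only; others in the source may bear on it.

Measured compounds:
compound 1 `CCc1ccc(C(=O)Nc2ccc(Nc3ncnc4cc(OC)c(OC)cc34)cc2)cc1`, 72000 nM
compound 2 `COc1cc2ncnc(Nc3ccc(NC(=O)c4ccc(C(C)(C)C)cc4)cc3)c2cc1OC`, a limit
compound 3 `COc1cc2ncnc(Nc3ccc(NC(=O)c4cccc(Cl)c4)cc3)c2cc1OC`, 12000 nM

All three share one core and differ only in the aryl group on the carbonyl. In a functional assay on HepG2 cells (Homo sapiens) for inhibition, read by MTT assay (a lower number here means a stronger inhibitor, a higher number a weaker inhibitor), compound 1 gives 72000 nM. Compound 2 gives > 100000 nM, which is a limit of the assay and not a number (the limit of > 100000 nM in this assay, at which 1 of the 3 values shown sits). Compound 3 gives 12000 nM and stands lowest of the two numbers; the step of a 6.0-fold lower number from compound 1 to compound 3 (0.78 log units; beyond the scatter) and the step of an at least 8.3-fold lower number from compound 2 to compound 3 (0.92 log units; beyond the scatter) both lie beyond the scatter, while an at least 1.3-fold higher number from compound 1 to compound 2 (0.14 log units; that floor lies within the scatter) does not.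

Compound 4 `COc1cc2ncnc(Nc3ccc(NC(=O)c4ccc(Cl)c(Cl)c4)cc3)c2cc1OC` has not been measured. It differs from compound 3 by chloro in place of hydrogen on an aromatic carbon. Among the measured compounds shown here, no measured step adds a second chloro to the 3-chlorophenyl; the two steps to compound 3 replace a para-alkyl aryl by the 3-chlorophenyl, and compound 1 and compound 2 each carry a para group on that ring. The new chloro enters para to a large group, where the para-alkyl compounds were the weaker ones, so for compound 4 a step of no change at the digits printed from compound 3 to compound 4 (within the scatter) is expected, not clearly beyond the scatter. The estimate for compound 4 is 12000 nM, with a range from 3000 nM to 45000 nM.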

Compound 4, half-maximal inhibitory concentration: 28000 nM
Beside the measured number, compound 4's estimate is 2.3-fold (0.37 log units) below it; low and high end bracket the measured number.
By their numbers in this assay, from the lowest: compound 3; then compound 4; then compound 1. At a limit, above all of these: compound 2.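

Among the compounds shown here, a second chloro on the 3-chlorophenyl, ortho to a chloro group and para to a large group, gives the first step in this assay that starts from compound 3 (a 2.3-fold higher number from compound 3 to compound 4 (0.37 log units; beyond the scatter)), and the number rises rather than falls. The 3,4-dichlorophenyl still keeps a lower number than either alkyl-bearing aryl (a 2.6-fold lower number from compound 1 to compound 4 (0.41 log units; beyond the scatter); an at least 3.5-fold lower number from compound 2 to compound 4 (0.55 log units; beyond the scatter)), so the 3-chloro pattern retains part of its advantage with a group at the new place. Compound 2 stands at a limit and not a number, so its step is only a floor: the limit of > 100000 nM in this assay, at which 1 of the 4 values shown sits.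

On these data alone, it stays open whether a methoxy, an amine or a carboxylic acid in place of the new chloro would move the number the same way. Chloro on that carbon appears only in compound 4, so whether its step depends on the neighbouring chloro also stays open.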